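A few compounds are considered here, and "the series" means these few. Any claim that something is new, unique, unknown or untested is made for them only; others in the source may bear on it.

Compound 1 `O=C(CCc1cccc2c1B(O)OC2)Nc1ccc(I)cc1`: 50000 nM
Compound 2 `O=C(CCc1cccc2c1B(O)OC2)Nc1cccc(Br)c1`: 1400 nM

Among the measured compounds shown here, in a functional assay on HCT-116 cells (Homo sapiens) for antiproliferative activity, read by MTT assay, with a stated time of 72 h (on this read-out higher numbers stand for weaker inhibition and lower numbers for stronger inhibition), compound 2 gives the lower of the two numbers, and the one measured step, a 36-fold lower number from compound 1 to compound 2 (1.55 log units; beyond the scatter), was large. Compound 3 `COc1cc(OC)cc(-c2cccc(NC(=O)CCc3cccc4c3B(O)OC4)c2)c1` differs from compound 2 by 3,5-dimethoxyphenyl in place of bromo on an aromatic carbon. That measured step swapped one halogen for another, so it does not bear on a change that brings in a 3,5-dimethoxyphenyl, and the two numbers give no direction for it. Compound 3 is therefore expected to stay close to compound 2, a 1.1-fold higher number from compound 2 to compound 3 (0.03 log units; within the scatter), with wide uncertainty. The estimate for compound 3 is 1500 nM, within 300 nM to 8000 nM.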

Compound 3, half-maximal inhibitory concentration: 53 nM
Estimate against measurement, compound 3: 28-fold (1.45 log units) above, outside the stated range (below it).
By their numbers in this assay, from the lowest: compound 3; then compound 2; then compound 1.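

The aromatic carbon that carries bromo in compound 2 also accepts a far larger group: in this assay the change to 3,5-dimethoxyphenyl gives a 26-fold lower number from compound 2 to compound 3 (1.42 log units; beyond the scatter) with one six-membered aromatic ring and 10 heavy atoms entering. The earlier step only exchanged one halogen-bearing aryl group for another, so it showed nothing about adding a ring at this place. No supporting data explain this step. Still open, from the compounds shown here alone, is whether the ring alone carries the step or its two methoxy groups contribute, which an unsubstituted phenyl would test. Going by these compounds, how a pyridine ring or an amine would behave here also remains unknown.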